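Replacing the Carboxy Group of Compound 1 with an Amide

The source may hold more compounds than are shown below. What is called first, only, known or untested is meant among the compounds shown, and "the series" means these compounds.

Compound 1 `COc1ccc(/C=C\c2cc(OC)c(OC)c(OC)c2)cc1OCc1ccc(CN2CCCCC2C(=O)O)cc1` gives 5400 nM in a functional assay on MC-38 cells (Mus musculus) for antiproliferative activity, read by CCK-8 assay, with a stated time of 48 h; a higher number here means a weaker inhibitor, a lower number a stronger inhibitor.
Compound 2 `COc1ccc(/C=C\c2cc(OC)c(OC)c(OC)c2)cc1OCc1ccc(CN2CC[C@H](C(=O)O)C2)cc1` reaches only the limit of this assay, > 10000 nM.
Compound 3 `COc1ccc(/C=C\c2cc(OC)c(OC)c(OC)c2)cc1OCc1ccc(CN2CC[C@@H](C(=O)O)C2)cc1` gives 6300 nM.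

Among the numbers shown, compound 1 has the lowest, with compound 3 nearest: a 1.2-fold higher number from compound 1 to compound 3 (0.07 log units; within the scatter). The move to compound 2 is an at least 1.8-fold higher number from compound 1 to compound 2 (0.26 log units; that floor lies within the scatter), resting on a limit (the limit of > 10000 nM in this assay, at which 1 of the 3 values shown sits). Compound 4 `COc1ccc(/C=C\c2cc(OC)c(OC)c(OC)c2)cc1OCc1ccc(CN2CCCCC2C(=O)NCCN)cc1` differs from compound 1 in one place: (2-aminoethyl)amino in place of hydroxy on a carbonyl carbon. Among the compounds with values here, none of the measured steps touches the carboxy group; they exchange the ring that carries it, or only its configuration as drawn (the fact that compounds 2 and 3 differ only in the configuration as drawn), as in an at least 1.5-fold lower number from compound 2 to compound 3 (0.20 log units; that floor lies within the scatter), and all stay within the scatter. There is thus no measured guide to the amide, and the expected step of a 1.2-fold lower number from compound 1 to compound 4 (0.08 log units; within the scatter) is taken as none beyond the scatter. Compound 4 is estimated at 4500 nM, between 1200 nM and 15000 nM.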

Compound 4, half-maximal inhibitory concentration: > 10000 nM
Compound 4: no number, only a limit; the forecaster's own chance of this, stated with the estimate: 20%; at least 2.2-fold (0.34 log units) between middle value and limit.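

In this assay, within the data shown here, compound 4 reaches only a limit, > 10000 nM, and it is the first compound changed at the carbonyl carbon itself. Putting (2-aminoethyl)amino in place of hydroxy gives an at least 1.8-fold higher number from compound 1 to compound 4 (0.26 log units; that floor lies within the scatter), and the comparison with the 3-carboxypyrrolidin-1-yl compound gives an at least 1.5-fold higher number from compound 3 to compound 4 (0.20 log units; that floor lies within the scatter), so the amide brings no lower number, while neither floor clears the scatter. The step from compound 2 to compound 4 cannot be read, since both ends are limits: the limit of > 10000 nM in this assay, at which 2 of the 4 values shown sit.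

Going by these compounds, it remains open how a methyl ester or an unsubstituted carboxamide on this carbonyl carbon would compare with compound 1. On these data alone, a longer chain than 2-aminoethyl, ending in a dimethylamino group, is equally open.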